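The compounds below may be only part of what the source reports. "The series", "measured", "known", "first", "only" and "open" are said of these compounds alone.

In an assay on HEK293 cells for displacement of a labelled ligand from Melanocortin receptor 4 (Homo sapiens) (a lower number here means a stronger inhibitor, a higher number a weaker inhibitor), compound 1, `CC(C)C[C@H](N)c1ccccc1N1CCN(C(=O)[C@H](C)Cc2ccc(Cl)cc2F)CC1`, gives 67 nM. Compound 2, `CC(C)C[C@H](N)c1cc(C(F)(F)F)ccc1N1CCN(C(=O)CCC(N)=O)CC1`, shares the same core but carries a trifluoromethyl group on its aromatic ring and a short, polar group on the carbonyl. For compound 2 this assay reports no number, only a limit, > 10000 nM; that is the limit of > 10000 nM in this assay, at which 1 of the 2 values shown sits.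

Compound 3, `CC(C)C[C@H](N)c1cc(C(F)(F)F)ccc1N1CCN(C(=O)COc2cccc(Cl)c2Cl)CC1`, differs from compound 2 in one place: 2,3-dichlorophenoxy in place of carbamoylmethyl on a saturated chain carbon bound to a carbonyl carbon. The entering group brings an aromatic ring with two chlorines, and compound 1, whose carbonyl also carries a chlorine-bearing aromatic ring, gives 67 nM in this assay. Within the data shown here, on that basis the expected step is an at least 33-fold lower number from compound 2 to compound 3 (1.52 log units; beyond the scatter), a large gain that goes well beyond the scatter, though only two measured compounds support this expectation. Compound 3 is therefore estimated at 300 nM, with a likely range from 50 nM to 3000 nM.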

Compound 3, inhibition constant: 2500 nM
Estimate against measurement, compound 3: 8.3-fold (0.92 log units) below; the measured number falls inside the stated range.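

In this assay, putting 2,3-dichlorophenoxy in place of carbamoylmethyl on a saturated chain carbon bound to a carbonyl carbon gives an at least 4.0-fold lower number from compound 2 to compound 3 (0.60 log units; beyond the scatter), so what sits at this place clearly changes the read-out. From the compounds shown here alone, the true size of this step remains unknown, and it may be larger, since compound 2 has only a limit and not a number: the limit of > 10000 nM in this assay, at which 1 of the 3 values shown sits. Compound 1 differs from compound 3 in more than one place, so this result cannot show how the two compare.

The compounds shown leave open which part of 2,3-dichlorophenoxy accounts for the lower number: the aromatic ring, the two chlorines or the oxygen. A plain phenoxy at the same place would begin to separate these, while an amine or a carboxylic acid there would test a quite different kind of group.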